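The source may hold more compounds than are shown below. What is called first, only, known or untested is meant among the compounds shown, and "the series" means these compounds.

Series notes. The shared core carries a carbonyl and a double-bonded chain ending in an aromatic group, the only site varied across these three compounds. Compound 1 `CNC(=O)c1cc(Oc2ccc(C(=O)/C=C/c3cccc([N+](=O)[O-])c3)cc2)ccn1` was made, but in a functional assay on A549 cells (Homo sapiens) for cytotoxicity, read by MTT assay, with a stated time of 72 h (on this read-out lower numbers stand for stronger inhibition and higher numbers for weaker inhibition), compound 1 has "not determined" (no result reported), so it offers no footing. Among the compounds with values here, compound 2 `CNC(=O)c1cc(Oc2ccc(C(=O)/C=C/c3ccc(Cl)cc3Cl)cc2)ccn1` is therefore the only compound with a number: in this assay compound 2 gives 9460 nM, and it stands alone, with nothing measured to rank it against.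

Compound 3 `CNC(=O)c1cc(Oc2ccc(C(=O)/C=C/c3ccc(F)cc3)cc2)ccn1` is the next entry to be measured. Its change from compound 2 is 4-fluorophenyl in place of 2,4-dichlorophenyl on a double-bonded chain carbon bound to a double-bonded chain carbon. Within the data shown here, no measured pair in this set isolates such a change, so there is no computed step to lean on, and any expectation rests on the single number for compound 2 and the structural change alone. The expected step in this assay is a 1.7-fold higher number from compound 2 to compound 3 (0.23 log units; within the scatter), a modest shift toward weaker inhibition that could still fall within scatter. Compound 3 is thus estimated at 16000 nM in this assay, with a range from 5000 nM to 50000 nM.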

Compound 3, half-maximal inhibitory concentration: 18600 nM
Compound 3: middle estimate off by 1.2-fold (0.07 log units), on the low side; the measured number falls inside the stated range.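

In this assay, within the data shown here, the exchange of 2,4-dichlorophenyl for 4-fluorophenyl on a double-bonded chain carbon bound to a double-bonded chain carbon gives a 2.0-fold higher number from compound 2 to compound 3 (0.29 log units; within the scatter) and provides the first measured pair at this position, which places compound 2 and compound 3 within the scatter of each other. Both groups are a six-membered aromatic ring of carbon only with no hydrogen-bond donors or acceptors and no net charge, so this pair shows that replacing two chlorine atoms with one fluorine atom on that ring does not separate the two compounds on this read-out, although the kind and the number of halogen atoms change together and cannot be told apart here. Nothing available explains this result or assigns a role to either group.

Among these compounds, the single pair leaves open whether any replacement at this position can move the number beyond the scatter, since it covers only two halogen-bearing phenyl groups. From the compounds shown here alone, a phenyl group carrying an amine or a carboxylic acid, or an unsubstituted phenyl, would test the position more widely, and the response to such groups remains unknown.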